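Moving One Nitrooxymethyl Group Around a Phenyl Ester

The compounds below may be only part of what the source reports. "The series", "measured", "known", "first", "only" and "open" are said of these compounds alone.

- Compound 1 (`CCCCc1nc(Cl)c(COC(=O)c2ccc(CO[N+](=O)[O-])cc2)n1Cc1ccc(-c2ccccc2-c2nn[nH]n2)cc1`): 66.1 nM
- Compound 2 (`CCCCc1nc(Cl)c(C(=O)Oc2cccc(CO[N+](=O)[O-])c2)n1Cc1ccc(-c2ccccc2-c2nn[nH]n2)cc1`): 6030 nM

Both values come from a functional assay (aorta, strain Wistar) for inhibition, with Rattus norvegicus as the target; a lower number here means a stronger inhibitor, a higher number a weaker inhibitor. In this assay, compound 2 gives 6030 nM, the higher of the two numbers and so the weaker inhibitor. The gap to compound 1 at 66.1 nM lies well beyond the usual scatter. These two compounds differ in more than one place, however, so their gap does not measure any single change.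

Compound 3 (`CCCCc1nc(Cl)c(C(=O)Oc2ccc(CO[N+](=O)[O-])cc2)n1Cc1ccc(-c2ccccc2-c2nn[nH]n2)cc1`) has the same atoms as compound 2, joined differently. It carries 4-((nitrooxy)methyl)phenyl in place of 3-((nitrooxy)methyl)phenyl on an oxygen next to a carbonyl group. Within the data shown here, no measured pair shows what this kind of move does, so the forecast is uncertain. Compound 1 at 66.1 nM shows only that much lower numbers occur among these close relatives, which leads to a cautious expectation of a moderate drop beyond the scatter. The expected move is a 4.0-fold lower number from compound 2 to compound 3 (0.60 log units; beyond the scatter). Compound 3 is expected at about 1500 nM, with an estimated range of 200 nM to 8000 nM.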

Compound 3, half-maximal inhibitory concentration: 275 nM
Compound 3: the middle estimate sits 5.5-fold (0.74 log units) above what was measured; the measured number falls inside the stated range.
By their numbers in this assay, from the lowest: compound 1; then compound 3; then compound 2.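

Among these compounds, the change from 3-((nitrooxy)methyl)phenyl to 4-((nitrooxy)methyl)phenyl, on an oxygen next to a carbonyl group, is the first single change that can be read, and in this assay it gives a 22-fold lower number from compound 2 to compound 3 (1.34 log units; beyond the scatter), a large step beyond the scatter. The group that leaves and the group that enters have the same atoms and the same counts of rings, double bonds, donors and acceptors, so this result shows that the number at this position depends strongly on how the nitrooxymethyl group is joined to the phenyl ring, not only on which atoms are present. The data at hand offer no measurement that explains this difference.

As far as these compounds go, it remains open whether the nitrooxy part itself matters here, a question that a simple hydroxymethyl group on the same phenyl ring could address. It is also unclear whether the same change would give a step of similar size with a longer chain, such as a nitrooxyethyl group, in place of the nitrooxymethyl group.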